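The source may hold more compounds than are shown below. What is called first, only, known or untested is meant among the compounds shown, and "the series" means these compounds.

Working notes on the series, read in a functional assay on K562 cells (Homo sapiens) for antiproliferative activity, read by MTT assay; on this read-out lower numbers stand for stronger inhibition and higher numbers for weaker inhibition. Compound 1 (`O=C(CCCCCNC(=S)NN=C(c1ccccn1)c1ccccn1)NO`) gives 2870 nM and compound 2 (`Cc1ccc(/C(=N/NC(=S)NCCCCCC(=O)NO)c2ccccc2)cc1`) gives 4340 nM, two values within the usual scatter of each other. Compound 3 (`C/C(=N\NC(=S)NCCCCCC(=O)NO)c1ccc(Br)cc1`) gives 960 nM, the lowest of the three numbers, and its gaps to compound 1 and to compound 2 both lie beyond the scatter. For the measured compounds named here, on these three values, compound 3 is the most potent compound measured so far.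

The next compound is compound 4 (`C/C(=N\NC(=S)NCCCCCC(=O)NO)c1ccc(F)cc1`), which differs from compound 3 in one place: fluoro in place of bromo on an aromatic carbon. This is fluoro in place of bromo on an aromatic carbon, para to a large group. Going by the values given here, no two measured compounds differ in one place only, so the data give no direct guide to the size of this step. Among the compounds with values here, with compound 3 at 960 nM as the lowest number so far, a move to a somewhat higher number in this assay is expected rather than a further drop. The estimated change is a 1.5-fold higher number from compound 3 to compound 4 (0.16 log units; within the scatter), which is expected to stay within the scatter or close to its edge. For compound 4 the estimated value is 1400 nM, with an expected range from 650 nM to 3000 nM.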

Compound 4, half-maximal inhibitory concentration: 1890 nM
Compound 4: middle estimate off by 1.4-fold (0.13 log units), on the low side, and the stated range covers the measured number.
By their numbers in this assay, from the lowest: compounds 3, 4, 1 and 2 (each within the scatter of the next, the first and the last beyond it).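

Fluoro in place of bromo on an aromatic carbon, para to a large group, gives a 2.0-fold higher number from compound 3 to compound 4 (0.29 log units; within the scatter) in this assay. This is the first pair in the series that differs in one place, and it shows that 4-bromophenyl and 4-fluorophenyl cannot be told apart at this position in this read-out, so compound 3 cannot be set apart from compound 4 on potency, and bromo is not shown to be needed at this carbon for a value in this range. No measurement of any property accompanies these two compounds, so the data offer no account of this result.

Going by these compounds, a single pair of halogens leaves open how much this carbon tolerates in general: whether chloro, methoxy, an amine or a carboxylic acid there would also stay within the scatter of compound 3 remains unknown, as does the effect of moving fluoro or bromo to another carbon of the ring. The compounds shown also leave open what a longer chain, in place of the one shared by compound 3 and compound 4, would do in this assay.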